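This account rests on a few compounds, and the source may have more. Where it says the series, first, only, none or still open, it means among the compounds named here.

Measured so far in a functional assay on Caco-2 cells (Homo sapiens) for antiproliferative activity, read by MTT assay, with a stated time of 48 h; a higher number here means a weaker inhibitor, a lower number a stronger inhibitor:
- compound 1 `CCN(CC)CCNC(=O)c1ccc(C(CC)(CC)c2ccc(OCCC(O)(CC)CC)c(C)c2)n1CC`: 1630 nM
- compound 2 `CCn1c(C(=O)NCC#N)ccc1C(CC)(CC)c1ccc(OCCC(O)(CC)CC)c(C)c1`: > 50000 nM
- compound 3 `CCOC(=O)CN(C)C(=O)c1ccc(C(CC)(CC)c2ccc(OCCC(O)(CC)CC)c(C)c2)n1CC`: 30300 nM

The entry for compound 2 is a limit of the assay, not a number. Of the two true numbers, compound 3 has the higher, and its nearest neighbour is compound 1: a 19-fold higher number from compound 1 to compound 3 (1.27 log units; beyond the scatter).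

Compound 4 `CCn1c(C(=O)NC(CC(=O)O)C(=O)OC)ccc1C(CC)(CC)c1ccc(OCCC(O)(CC)CC)c(C)c1` changes the group on the carbonyl carbon of compound 3: a group of 10 heavy atoms (5 carbon, 1 nitrogen, 4 oxygen; no ring) in place of a group of 8 heavy atoms (5 carbon, 1 nitrogen, 2 oxygen; no ring), on a carbonyl carbon. The steps at this carbonyl carbon bear on it. Losing the (2-(diethylamino)ethyl)amino group of compound 1 was large both times: a 19-fold higher number from compound 1 to compound 3 (1.27 log units; beyond the scatter), and an at least 30-fold higher number from compound 1 to compound 2 (1.48 log units; beyond the scatter). Compound 4 also lacks that group, so no return towards compound 1 is expected. Between the two groups without it, the evidence is only an at least 1.6-fold lower number from compound 2 to compound 3 (0.21 log units; that floor lies within the scatter).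

In this assay, the expected step is small: a 1.3-fold higher number from compound 3 to compound 4 (0.12 log units; within the scatter). The estimate for compound 4 is 40000 nM, expected between 15000 nM and 80000 nM.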

Compound 4, half-maximal inhibitory concentration: 25200 nM
Estimate against measurement, compound 4: 1.6-fold (0.20 log units) above; the range from low to high includes it.
By their numbers in this assay, from the lowest: compound 1; then compounds 4 and 3 (each within the scatter of the next). At a limit, above all of these: compound 2.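

In this assay, the two groups on the carbonyl carbon without the (2-(diethylamino)ethyl)amino group are not separated, despite their different makeup: a 1.2-fold lower number from compound 3 to compound 4 (0.08 log units; within the scatter). Loss of that group is large for a third compound: a 15-fold higher number from compound 1 to compound 4 (1.19 log units; beyond the scatter). Compound 2 stands at a limit of the assay, so an at least 1.9-fold lower number from compound 2 to compound 4 (0.29 log units; that floor lies within the scatter) cannot be read as a size: the limit of > 50000 nM in this assay, at which 1 of the 4 values shown sits.

On these data alone, whether the lower number of compound 1 belongs to the diethylamino group or to the chain carrying it stays open. A dimethylamino group or a longer chain on the amide-type nitrogen would bear on this.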